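Ethynyl in place of thiophen-2-yl on a shared core

This account rests on a few compounds, and the source may have more. Where it says the series, first, only, none or still open, it means among the compounds named here.

compound 1 `COc1ncnc2c1c(-c1ccccc1)cn2[C@@H]1O[C@H](CO)[C@@H](O)[C@H]1O`: > 20000 nM (a limit of the assay)
compound 2 `COc1ncnc2c1c(-c1cc3ccccc3o1)cn2[C@@H]1O[C@H](CO)[C@@H](O)[C@H]1O`: 9240 nM
compound 3 `CSc1ncnc2c1c(-c1cccs1)cn2[C@@H]1O[C@H](CO)[C@@H](O)[C@H]1O`: 1960 nM

All three compounds were tested in a functional assay on HeLa S3 cells (Homo sapiens) for antiproliferative activity, read by XTT assay, with a stated time of 72 h; a lower number here means a stronger inhibitor, a higher number a weaker inhibitor. The entry for compound 1 is a limit of the assay and not a number. Of the two actual numbers, compound 2 gives 9240 nM and compound 3 gives 1960 nM. The number of compound 3 is the lower of the two, and the gap between them is beyond the scatter.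

Compound 4 (`C#Cc1cn([C@@H]2O[C@H](CO)[C@@H](O)[C@H]2O)c2ncnc(SC)c12`) differs from compound 3 by a single change (ethynyl in place of thiophen-2-yl on an aromatic carbon). Among the measured compounds shown here, only one measured step bears on this change, and only loosely: an at least 2.1-fold lower number from compound 1 to compound 2 (0.33 log units; beyond the scatter). It too exchanges one group for another on an aromatic carbon, but it starts from a limit (the limit of > 20000 nM in this assay, at which 1 of the 3 values shown sits) and swaps one ring group for another, whereas here a ring group leaves and a group with no ring enters. For the measured compounds named here, no measured step shows what ethynyl does, so neither direction is favoured, and in this assay no step beyond the scatter is expected. The expected step is small (a 1.3-fold lower number from compound 3 to compound 4 (0.12 log units; within the scatter)) and uncertain. For compound 4 the estimated value is 1500 nM, with an expected range from 200 nM to 10000 nM.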

Compound 4, half-maximal inhibitory concentration: 110 nM
Compound 4: middle estimate off by 14-fold (1.13 log units), on the high side; measured number below the stated range.
By their numbers in this assay, from the lowest: compound 4; then compound 3; then compound 2. At a limit, above all of these: compound 1.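

In this assay, the step of an 18-fold lower number from compound 3 to compound 4 (1.25 log units; beyond the scatter) shows that this position, on an aromatic carbon of the five-membered aromatic ring with 1 nitrogen, can carry a group with no ring and give a much lower number than a ring group does. The earlier step of an at least 2.1-fold lower number from compound 1 to compound 2 (0.33 log units; beyond the scatter) could not show this, as it started from a limit and only exchanged one ring group for another, whereas here thiophen-2-yl with its 5 heavy atoms gives way to ethynyl with 2 heavy atoms and a triple bond. Nothing measured among these compounds accounts for the size of this step.

A single pair leaves open whether the triple bond itself or simply the loss of the ring goes with the lower number, and groups such as vinyl, ethyl, nitrile or a longer alkynyl chain at this position would bear on that. As far as these compounds go, it also remains open whether ethynyl gives a similar step on the methoxy-bearing core of compound 1 and compound 2.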